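The source may hold more compounds than are shown below. What is called first, only, known or untested is meant among the compounds shown, and "the series" means these compounds.

Compound 1 `COc1ccc(/C=C/C(=O)/C=C/c2ccc(OCc3cn(CCCCCOc4cc(=O)oc5ccccc45)nn3)c(OC)c2)cc1OC` and compound 2 `COc1cccc(/C=C/C(=O)/C=C/c2ccc(OCc3cn(CCCCCOc4cc(=O)oc5ccccc45)nn3)c(OC)c2)c1` share a core; in a functional assay on HCT-116 cells (Homo sapiens) for inhibition, read by sulforhodamine B assay, with a stated time of 48 h, tested at 50 uM (on this read-out higher numbers stand for more inhibition of growth at the one concentration tested and lower numbers for less inhibition of growth), compound 1 gives 45% and compound 2 gives 36%. The change hydrogen in place of methoxy on an aromatic carbon made the step of a number 9 percentage points lower from compound 1 to compound 2 (within the scatter). Compound 3 `COc1cc(/C=C/C(=O)/C=C/c2cc(OC)c(OC)c(OC)c2)ccc1OCc1cn(CCOc2cc(=O)oc3ccccc23)nn1` is built on a second core, and how the two cores differ is not broken down here. In this assay compound 3 gives 89%. Compound 4 `COc1ccc(/C=C/C(=O)/C=C/c2ccc(OCc3cn(CCOc4cc(=O)oc5ccccc45)nn3)c(OC)c2)cc1OC` arises from compound 3 by hydrogen in place of methoxy on an aromatic carbon, the same kind of change as from compound 1 to compound 2, though here the place is also meta to a large group and meta to a methoxy group rather than para to a large group. Because the earlier step of a number 9 percentage points lower from compound 1 to compound 2 (within the scatter) was small, a modest step of a number 14 percentage points lower from compound 3 to compound 4 (beyond the scatter) is expected. Compound 4 is thus estimated at 75%, in the range 55% to 92%.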

Compound 4, percent growth inhibition at one concentration: 82%
Compound 4: the middle estimate sits 7 percentage points below what was measured; low and high end bracket the measured number.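

Putting hydrogen in place of methoxy, which here turns 3,4,5-trimethoxyphenyl into 3,4-dimethoxyphenyl, gave a number 7 percentage points lower from compound 3 to compound 4 (within the scatter) in this assay. Set beside the earlier step, the change carried across the two cores with much the same small size: the same change on two cores in this assay, a number 9 percentage points lower (within the scatter) from compound 1 to compound 2 and a number 7 percentage points lower (within the scatter) from compound 3 to compound 4, 2 percentage points apart, within the scatter of two such steps This shows only that the swap made no step beyond the scatter in these two pairs, which differ in where on the ring it falls; it does not show that the same would hold on any other core or at another concentration.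

Only hydrogen and methoxy appear at this place among the compounds shown. On these data alone, whether an amine or a carboxylic acid there would shift growth inhibition remains open.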